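This account rests on a few compounds, and the source may have more. Where it says the series, first, only, none or still open, it means among the compounds named here.

Notes on the series. Compound 1 `C=CCCCCCC#CC#CCO` and compound 2 `C=CCCCCCCCC#CC#CCO` have been measured in a functional assay on SK-OV-3 cells (Homo sapiens) for cytotoxicity; on this read-out higher numbers stand for an effect only at larger amounts of compound and lower numbers for an effect already at smaller amounts. Compound 1 gives 9.79 ug/mL, and compound 2 gives 3.23 ug/mL. For the measured compounds named here, the one step measured so far, a 3.0-fold lower number from compound 1 to compound 2 (0.48 log units; beyond the scatter), was modest and lies beyond the scatter. Going by the values given here, on these two numbers compound 2 stands lowest, with compound 1 as its only neighbour.

Compound 3 `CCCCCCCC#CC#CCO` is not yet measured. It differs from compound 2 as follows: hydrogen in place of vinyl on a saturated chain carbon, seven bonds along the chain from a triple-bonded carbon. The change runs opposite in sense to the step from compound 1 to compound 2, since the chain of compound 3 is cut back to a size close to that of compound 1 while the double bond is lost. Among the compounds with values here, only the step from compound 1 to compound 2 bears on this, and it argues that shortening the chain again should send the number back upward by a modest amount. For compound 3 a step of about a 2.5-fold higher number from compound 2 to compound 3 (0.39 log units; beyond the scatter) is therefore expected, in the direction of a higher number. The estimate for compound 3 in this assay is 8 ug/mL, with a range from 3 ug/mL to 20 ug/mL.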

Compound 3, concentration for half-maximal effect: 4.63 ug/mL
The estimate for compound 3 lay 1.7-fold (0.24 log units) above the measured number, and the stated range covers the measured number.
By their numbers in this assay, from the lowest: compounds 2 and 3 (each within the scatter of the next); then compound 1.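

Losing the vinyl group at this place, seven bonds along the chain from a triple-bonded carbon, leaves this assay unable to separate the two saturated and unsaturated chain ends (a 1.4-fold higher number from compound 2 to compound 3 (0.16 log units; within the scatter)). The double bond outside aromatic rings is therefore not needed for a number in the range of compound 2, and the saturated compound 3 keeps that range. Ethyl in place of vinyl, five bonds along the chain from a triple-bonded carbon, does register as a modest step (a 2.1-fold lower number from compound 1 to compound 3 (0.33 log units; beyond the scatter)), so the vinyl group of compound 1 and the ethyl group of compound 3 can be told apart at that place, while no measurement at hand accounts for either step.

As far as these compounds go, whether a longer saturated chain would carry the number lower stays open. So does what a phenyl group or an amine on the saturated chain carbon would give.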